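A few compounds are considered here, and "the series" means these few. Any claim that something is new, unique, unknown or untested is made for them only; others in the source may bear on it.

Measured in a functional assay on HeLa cells (Homo sapiens) for antiproliferative activity, read by CCK-8 assay, with a stated time of 72 h, tested at 8 uM; on this read-out lower numbers stand for a weaker effect and higher numbers for a stronger effect at the one concentration tested:

compound 1 `Nc1ccccc1NC(=O)c1ccc(CSC(=S)N2CCN(C(c3ccccc3)c3ccccc3)CC2)cc1`: 13.8%
compound 2 `CN(C(=S)SCc1ccc(C(=O)Nc2ccccc2N)cc1)c1cccnc1`: 70.5%
compound 3 `COc1ccc(N2CCN(C(=S)SCc3ccc(C(=O)Nc4ccccc4N)cc3)CC2)cc1`: 52.3%

Compound 3 stands second highest of the three numbers in this assay. Its nearest neighbour is compound 2, whose number lies higher by a gap beyond the scatter; furthest is compound 1, whose number lies lower, again beyond the scatter. Among the compounds with values here, no pair among the measured compounds differs in one place only, so no single-change step within this assay is at hand to lean on.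

Compound 4 `Cc1ccc(N2CCN(C(=S)SCc3ccc(C(=O)Nc4ccccc4N)cc3)CC2)cc1` differs from compound 3 by methyl in place of methoxy on an aromatic carbon, the change sitting on an aromatic carbon of a six-membered aromatic ring of carbon only. Within the data shown here, with no comparable step among the measured compounds, the expected step of a number 2.3 percentage points lower from compound 3 to compound 4 (within the scatter) is taken as small, in no fixed direction and not beyond the scatter. Compound 4 is therefore estimated at 50% in this assay, with a range from 30% to 70%.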

Compound 4, a percentage reported as inhibition, at one concentration (the size of the read-out at that concentration, not a potency): 24%
Compound 4: middle estimate off by 26 percentage points, on the high side; the measured number lies below the stated range.
By their numbers in this assay, from the lowest: compound 1; then compound 4; then compound 3; then compound 2.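

In this assay, this first single-change step in the series, on an aromatic carbon para to a large group, gives a number 28.3 percentage points lower from compound 3 to compound 4 (beyond the scatter). The result shows that this position is not indifferent to what it carries: even the small change from 4-methoxyphenyl to 4-methylphenyl moves the read-out. No measurement at hand bears on the reason for this step.

One step cannot separate a gain from methoxy from a loss with methyl. Also open, as far as these compounds go, is how a hydroxyl, an amine or a chlorine atom on the same carbon would read.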